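Swapping the benzyl substituent on a shared thiourea core

The source may report more compounds than this note shows. Statements on the series, on what has been measured and on what is new or still open speak of the compounds shown alone.

Measured so far:
compound 1 `Cc1ccc(NC(=S)NC(=O)c2ccc(OCc3ccc(C(F)(F)F)cc3)cc2)cc1-c1nc2ccccc2[nH]1` — a functional assay on SW-620 cells (Homo sapiens) for inhibition, read by MTT assay, with a stated time of 48 h; a higher number here means a weaker inhibitor, a lower number a stronger inhibitor: 72400 nM
compound 2 `Cc1ccc(NC(=S)NC(=O)c2ccc(OCc3ccccc3F)cc2)cc1-c1nc2ccccc2[nH]1` — this assay: 6440 nM

Compound 2 stands at the lower of the two numbers. For the measured compounds named here, its only neighbour is compound 1, and the single step between them, an 11-fold lower number from compound 1 to compound 2 (1.05 log units; beyond the scatter), is large and beyond the scatter. The two compounds differ only in the aromatic group on the saturated chain carbon bound to the oxygen on the aromatic ring.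

Compound 3 `Cc1ccc(NC(=S)NC(=O)c2ccc(OCc3cccc(Cl)c3Cl)cc2)cc1-c1nc2ccccc2[nH]1` keeps everything else and changes that same position: 2,3-dichlorophenyl in place of 2-fluorophenyl on a saturated chain carbon bound to an oxygen on an aromatic ring. The step from compound 1 to compound 2 is the only one that bears on this change. It shows that exchanging the aromatic group at this position can move the number a great deal, but it gives no guide to which direction a 2,3-dichlorophenyl group will take, since neither measured compound carries chlorine. The expected step from compound 2 to compound 3 is therefore modest and uncertain, a 1.6-fold higher number from compound 2 to compound 3 (0.19 log units; within the scatter). The estimate for compound 3 in this assay is 10000 nM, with a range from 2500 nM to 40000 nM.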

Compound 3, half-maximal inhibitory concentration: > 100000 nM
Compound 3: only a limit was reported; the forecaster's own chance of this, stated with the estimate: 15%; middle value at least 10-fold (1.00 log units) away from the limit.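

In this assay compound 3 gave only a limit of the assay, not a number: the limit of > 100000 nM in this assay, at which 1 of the 3 values shown sits. Even read as a floor, the change to 2,3-dichlorophenyl gives an at least 15-fold higher number from compound 2 to compound 3 (1.19 log units; beyond the scatter), so the earlier finding that the aromatic group on this saturated chain carbon matters now extends to a second large step, this time towards a higher number and starting from the better of the two measured compounds. The comparison with the 4-(trifluoromethyl)phenyl compound is less firm, with an at least 1.3-fold higher number from compound 1 to compound 3 (0.14 log units; that floor lies within the scatter), and that floor alone does not settle whether compound 3 truly differs from compound 1.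

These three compounds cannot tell whether the higher number for compound 3 goes with chlorine itself, with the presence of two substituents on the ring, or with the places they occupy. Going by these compounds, a phenyl group carrying a single chlorine, an unsubstituted phenyl group or a pyridine ring at this position would help to separate those readings, and their numbers remain open here.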